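Isomeric hydroxy-methoxyphenyl swap on the arylidene chain carbon

The source may report more compounds than this note shows. Statements on the series, on what has been measured and on what is new or still open speak of the compounds shown alone.

- compound 1 `COc1cccc(/C=C/C(=O)C(=Cc2cc(OC)c(OC)c(OC)c2)C(=O)/C=C/c2cccc(OC)c2OC)c1OC` gives 840 nM
- compound 2 `COc1ccc(OC)c(/C=C/C(=O)C(=Cc2ccc(O)c(OC)c2)C(=O)/C=C/c2cc(OC)ccc2OC)c1` gives 400 nM

Both numbers come from a functional assay on MCF7 cells (Homo sapiens) for antiproliferative activity, read by sulforhodamine B assay, with a stated time of 48 h; on this read-out lower numbers stand for stronger inhibition and higher numbers for weaker inhibition. Compound 2 stands lowest of the two at 400 nM and compound 1 lies higher at 840 nM with a gap beyond the usual scatter. Going by the values given here, the two compounds differ in more than one place, so this gap gives no measured step for any single change.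

Compound 3 `COc1ccc(OC)c(/C=C/C(=O)C(=Cc2ccc(OC)c(O)c2)C(=O)/C=C/c2cc(OC)ccc2OC)c1` is still unmeasured in this assay and departs from compound 2 in one place, with 3-hydroxy-4-methoxyphenyl in place of 4-hydroxy-3-methoxyphenyl on a double-bonded chain carbon bound to a double-bonded chain carbon. Among the compounds with values here, the series holds no measured example of this swap. The expectation therefore stays anchored on compound 2 at 400 nM as the closest measured structure, with no firm direction and no change expected beyond the scatter. The estimated step of a 1.1-fold higher number from compound 2 to compound 3 (0.05 log units; within the scatter) is expected to be small. In this assay the estimate for compound 3 is 450 nM with an expected range from 160 nM to 1300 nM for a single measurement.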

Compound 3, half-maximal inhibitory concentration: 990 nM
Estimate against measurement, compound 3: 2.2-fold (0.34 log units) below, within the range that was stated.
By their numbers in this assay, from the lowest: compound 2; then compounds 1 and 3 (each within the scatter of the next).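

In this assay, going by these compounds alone, the swap of 4-hydroxy-3-methoxyphenyl for 3-hydroxy-4-methoxyphenyl on a double-bonded chain carbon bound to a double-bonded chain carbon gives a 2.5-fold higher number from compound 2 to compound 3 (0.39 log units; beyond the scatter) as the only single-place step. The two groups hold the same atoms and the same counts of donors and acceptors, so the read-out at this position responds to how the hydroxy and methoxy groups are arranged on the ring, and not only to which groups are present, with 4-hydroxy-3-methoxyphenyl giving the lower number in this one pair. No measurement at hand bears on the reason for this step.

As far as these compounds go, whether the same preference holds with other aryl groups on the two outer chains stays open, as this single pair shares one set of dimethoxyphenyl groups and compound 1 differs from both in more than one place. Also open, from the compounds shown here alone, is whether the hydroxy group can be exchanged at this position, for instance whether an amine or a carboxylic acid in its place would keep the number of compound 2 or lose it.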